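The source may hold more compounds than are shown below. What is called first, only, known or untested is meant among the compounds shown, and "the series" means these compounds.

Values measured so far in an ADME assay on Vero cells (Chlorocebus sabaeus) for cytotoxicity, read by MTT assay, with a stated time of 72 h (on this read-out lower numbers stand for stronger inhibition and higher numbers for weaker inhibition), are:

Compound 1 `CCC[S+]([O-])CCCCN=C=S` gives 5640 nM
Compound 2 `CC(C)[S+]([O-])CCCCN=C=S` gives 10400 nM

Compound 1 has a single measured neighbour, and the two values lie within the scatter of each other. The record shows a 1.8-fold higher number from compound 1 to compound 2 (0.27 log units; within the scatter) with isopropyl in place of propyl on a sulfur.

Still unmeasured is compound 3 `[O-][S+](CCCCN=C=S)Cc1ccco1` which has furan-2-yl in place of ethyl on a saturated chain carbon bound to a sulfur on the shared core.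

Among the measured compounds shown here, only one measured step bears on this change, and it exchanges one open chain for another. For the measured compounds named here, no measured compound carries a ring at this place, so the guide is weak. Resting on a 1.8-fold higher number from compound 1 to compound 2 (0.27 log units; within the scatter) as the only measured step, no shift beyond the scatter is expected in this assay in either direction. The estimated step is a 1.1-fold higher number from compound 1 to compound 3 (0.03 log units; within the scatter) and it remains an expectation with wide uncertainty. For compound 3 the expected value is 6000 nM with an estimated range from 2200 nM to 16000 nM for now.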

Compound 3, half-maximal inhibitory concentration: 5250 nM
Compound 3: the middle estimate sits 1.1-fold (0.06 log units) above what was measured; measured number inside the range.
By their numbers in this assay, from the lowest: compounds 3, 1 and 2 (each within the scatter of the next).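

In this assay, among the compounds shown here, furan-2-yl in place of ethyl on a saturated chain carbon bound to a sulfur gives a 1.1-fold lower number from compound 1 to compound 3 (0.03 log units; within the scatter), the first reading for a ring at this place. The earlier step, a 1.8-fold higher number from compound 1 to compound 2 (0.27 log units; within the scatter), exchanged only one open chain for another, whereas this one shows that one five-membered aromatic ring with 1 hetero atom can enter here without a shift beyond the scatter. No measurement at hand bears on why these steps stay so small.

It remains open whether this holds for other groups at this place, such as a phenyl ring, an amine or a carboxylic acid, since furan-2-yl is the only ring shown there. Also open, going by these compounds, is how the values respond to changes elsewhere on the shared core, for example a longer chain or a nitrile in place of the isothiocyanate, as all three compounds differ only in the group on the sulfur.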